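Swapping fluoro for methoxy on the benzyl group

The source may hold more compounds than are shown below. What is called first, only, known or untested is meant among the compounds shown, and "the series" means these compounds.

Going by the values given here, compound 2 (`Nc1cc(N)c2nc(-c3ccccc3)c(NCc3ccc(F)cc3)nc2c1`) is the one compound of this pair with a number: in a functional assay on RXF 393 cells (Homo sapiens) for inhibition, read by sulforhodamine B assay, with a stated time of 48 h (a higher number here means a weaker inhibitor of growth, a lower number a stronger inhibitor of growth), compound 2 gives 26900 nM. Compound 1 (`COc1ccc(CNc2nc3cc(N)cc(N)c3nc2-c2ccccc2)cc1OC`) gives only a limit of this assay, < 100000 nM, not a number. Among the compounds with values here, the single measured step, a step that the limit leaves unreadable from compound 1 to compound 2, therefore cannot be read in size due to the limit of < 100000 nM in this assay, at which 1 of the 2 values shown sits. Compound 3 (`COc1ccc(CNc2nc3cc(N)cc(N)c3nc2-c2ccccc2)cc1`) differs from compound 2 by methoxy in place of fluoro on an aromatic carbon. No measured step covers this change, and the only step shown is unreadable, so nothing in the data points to a direction. The expected step of a 1.1-fold higher number from compound 2 to compound 3 (0.05 log units; within the scatter) is therefore one that stays within the usual scatter. Compound 3 is estimated at 30000 nM in this assay, with a range from 10000 nM to 90000 nM.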

Compound 3, concentration for total growth inhibition: 18200 nM
Compound 3: the middle estimate sits 1.6-fold (0.22 log units) above what was measured; the range from low to high includes it.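

Going by these compounds alone, replacing 4-fluorobenzyl with 4-methoxybenzyl gives the first readable step at this position: in this assay, the change is a 1.5-fold lower number from compound 2 to compound 3 (0.17 log units; within the scatter). Fluoro and methoxy therefore cannot be told apart here, even though methoxy brings one more heavy atom and a hydrogen-bond acceptor. The value for compound 1 remains a limit rather than a number, so neither step involving it can be read, and the effect of its extra methoxy stays unknown: the limit of < 100000 nM in this assay, at which 1 of the 3 values shown sits.

The compounds shown leave open whether any group at this position can shift the number beyond the usual scatter. An amine, a carboxylic acid or a longer chain such as butoxy, each on the same aromatic carbon, would test this more widely than two groups that match within the scatter.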